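Working notes: replacing the 4-methoxyphenyl on the carbonyl carbon

The source may hold more compounds than are shown below. What is called first, only, known or untested is meant among the compounds shown, and "the series" means these compounds.

In a functional assay on MCF7 cells (Homo sapiens) for cytotoxicity, read by MTT assay, with a stated time of 48 h (on this read-out lower numbers stand for stronger inhibition and higher numbers for weaker inhibition), compound 1 (`CCN(CC)C(=S)SC(CC(=O)c1ccccc1)c1ccc(C)cc1`) gives 20000 nM and compound 2 (`CCN(CC)C(=S)SC(CC(C)=O)c1ccccc1`) gives 23000 nM. Compound 3 (`CCN(CC)C(=S)SC(CC(=O)c1ccc(OC)cc1)c1ccccc1`) stands lowest of the three at 4500 nM. Compound 4 (`CCN(CC)C(=S)SC(CC(=O)c1ccc(Cl)c(Cl)c1)c1ccccc1`) remains unmeasured. The change is 3,4-dichlorophenyl in place of 4-methoxyphenyl on a carbonyl carbon. For the measured compounds named here, the one measured step at this place, 4-methoxyphenyl in place of methyl, is a 5.1-fold lower number from compound 2 to compound 3 (0.71 log units; beyond the scatter). Going by the values given here, that step shows that the place can move the number, but no measured step exchanges one substituted phenyl for another. No step beyond the scatter is therefore expected. The estimated step is a 1.2-fold higher number from compound 3 to compound 4 (0.09 log units; within the scatter). The estimate for compound 4 is 5500 nM, with an expected range of 2000 nM to 16000 nM.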

Compound 4, half-maximal inhibitory concentration: 4500 nM
Beside the measured number, compound 4's estimate is 1.2-fold (0.09 log units) above it, within the range that was stated.
By their numbers in this assay, from the lowest: compounds 3 and 4 (each within the scatter of the next); then compounds 1 and 2 (each within the scatter of the next).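

In this assay, exchanging one substituted phenyl for another on the carbonyl carbon gives no change at the digits printed from compound 3 to compound 4 (within the scatter) in this series, so the lower number does not rest on the 4-methoxyphenyl alone. Measured against the methyl, 3,4-dichlorophenyl gives a 5.1-fold lower number from compound 2 to compound 4 (0.71 log units; beyond the scatter) at this place, matching the step seen with 4-methoxyphenyl. No supporting measurement bears on why these two groups read alike.

Still open, from the compounds shown here alone, is whether a phenyl carrying an amine or a carboxylic acid would hold this level. Going by these compounds, whether a longer chain in place of methyl would do so is also open.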